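Adding an oxygen to the methylsulfanyl group

The source may report more compounds than this note shows. Statements on the series, on what has been measured and on what is new or still open speak of the compounds shown alone.

Values in a functional assay on the whole organism with Rattus norvegicus as the target (on this read-out lower numbers stand for an effect already at smaller amounts and higher numbers for an effect only at larger amounts of compound), so far
Compound 1 `CCCCn1c(=N)sc2cc(OC(F)(F)F)ccc21` gives 10 mg/kg
Compound 2 `COC(=O)Cn1c(=N)sc2cc(OC(F)(F)F)ccc21` gives > 10 mg/kg as a limit of the assay, not a number
Compound 3 `CSCn1c(=N)sc2cc(OC(F)(F)F)ccc21` gives 3 mg/kg

Among the measured compounds shown here, compound 3 stands lowest of the numbers so far. Compound 4 (`C[S+]([O-])Cn1c(=N)sc2cc(OC(F)(F)F)ccc21`) keeps the shared core and changes only the group on a saturated chain carbon bound to an aromatic nitrogen (a group of 3 heavy atoms (1 carbon, 1 oxygen, 1 sulfur; no ring) in place of a group of 2 heavy atoms (1 carbon, 1 sulfur; no ring), on a saturated chain carbon bound to an aromatic nitrogen). For the measured compounds named here, no measured step makes this exact change. Both measured changes at this place led to methylsulfanyl and lowered the number (a 3.3-fold lower number from compound 1 to compound 3 (0.52 log units; beyond the scatter)) and (an at least 3.3-fold lower number from compound 2 to compound 3 (0.52 log units; beyond the scatter)), so leaving that group is expected to bring a modest rise in this assay rather than a further fall. The expected step runs (a 2.3-fold higher number from compound 3 to compound 4 (0.37 log units; beyond the scatter)). Compound 4 is estimated at 7 mg/kg within a range of (2.5 mg/kg to 20 mg/kg).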

Compound 4, dose for half-maximal effect: 2.3 mg/kg
For compound 4 the middle estimate is 3.0-fold (0.48 log units) above the measured one; the measured number lies below the stated range.
By their numbers in this assay, from the lowest: compounds 4 and 3 (each within the scatter of the next); then compound 1.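

The oxygen added to the sulfur leaves the number in this assay within the scatter (a 1.3-fold lower number from compound 3 to compound 4 (0.12 log units; within the scatter)), so at this place on a saturated chain carbon bound to an aromatic nitrogen, the sulfur group accepts that change. Compound 4 also keeps the distance from the propyl group (a 4.3-fold lower number from compound 1 to compound 4 (0.64 log units; beyond the scatter)) and from the methoxycarbonyl group (an at least 4.3-fold lower number from compound 2 to compound 4 (0.63 log units; beyond the scatter)). The value of compound 2 is a limit of the assay, not a number: the limit of > 10 mg/kg in this assay, at which 1 of the 4 values shown sits.

On these data alone, whether a second oxygen on the sulfur, as in a methylsulfonyl group, would hold the number stays open. So does the effect of an amine at this place.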